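Notes on the arylethynyl set: a pyridin-3-yl step

The source may hold more compounds than are shown below. What is called first, only, known or untested is meant among the compounds shown, and "the series" means these compounds.

Of the compounds shown here, three on a shared core have been measured in an assay on CHO cells for displacement of a labelled ligand from adenosine receptor A1 (Homo sapiens), read by scintillation counting, with a stated time of 60 min, tested at 10 uM; a higher number here means more inhibition at the concentration tested (going by the name of the read-out), a lower number less inhibition. Compound 1 `CNC(=O)[C@@]12C[C@@H]1[C@@H](n1cnc3c(NC)nc(C#Cc4cccc(F)c4)nc31)[C@H](O)[C@@H]2O` gives 14%, compound 2 `CNC(=O)[C@@]12C[C@@H]1[C@@H](n1cnc3c(NC)nc(C#Cc4ccc(F)cc4)nc31)[C@H](O)[C@@H]2O` gives 27% and compound 3 `CNC(=O)[C@@]12C[C@@H]1[C@@H](n1cnc3c(NC)nc(C#Cc4ccc(OC)cc4)nc31)[C@H](O)[C@@H]2O` gives 10%. Moving the fluoro from 3-fluorophenyl to 4-fluorophenyl on the triple-bonded carbon gives a modest rise, a number 13 percentage points higher from compound 1 to compound 2 (beyond the scatter). For the measured compounds named here, compound 3 lies within the scatter of compound 1 (a number 4 percentage points lower from compound 1 to compound 3 (within the scatter)) but beyond the scatter below compound 2 (a number 17 percentage points lower from compound 2 to compound 3 (beyond the scatter)), so the only change among the three that stands out is methoxy in place of fluoro on the aromatic carbon.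

Compound 4 `CNC(=O)[C@@]12C[C@@H]1[C@@H](n1cnc3c(NC)nc(C#Cc4cccnc4)nc31)[C@H](O)[C@@H]2O` is not yet measured in this assay. It differs from compound 3 in one place: pyridin-3-yl in place of 4-methoxyphenyl on a triple-bonded carbon. Going by the values given here, the steps that bear on this are the three exchanges of the aromatic ring on the triple-bonded carbon, a number 13 percentage points higher from compound 1 to compound 2 (beyond the scatter), a number 17 percentage points lower from compound 2 to compound 3 (beyond the scatter) and a number 4 percentage points lower from compound 1 to compound 3 (within the scatter); none of them puts a nitrogen into that ring, and all three numbers sit in a narrow band. The step from compound 3 to compound 4 is therefore expected to be small, a number 5 percentage points higher from compound 3 to compound 4 (within the scatter), with no direction that clears the scatter. Compound 4 is expected to give 15% in this assay, within a range of 3% to 30%.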

Compound 4, a percentage reported as inhibition, at one concentration (the size of the read-out at that concentration, not a potency): 16%
Beside the measured number, compound 4's estimate is 1 percentage points below it; measured number inside the range.
By their numbers in this assay, from the lowest: compounds 3, 1 and 4 (each within the scatter of the next); then compound 2.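

In this assay, for the compounds shown here, this is the first ring on the triple-bonded carbon to carry a nitrogen, and the change does not separate it from the carbon-only rings 4-methoxyphenyl and 3-fluorophenyl: a number 6 percentage points higher from compound 3 to compound 4 (within the scatter) and a number 2 percentage points higher from compound 1 to compound 4 (within the scatter). Only 4-fluorophenyl stands apart from pyridin-3-yl, with a number 11 percentage points lower from compound 2 to compound 4 (beyond the scatter), so among the four compounds compound 2 alone clears the scatter against each of the others, and compounds 1, 3 and 4 form one group. At this position, then, exchanging a carbon-only ring for a ring with a hetero atom has no readable effect on its own, and no measurement on hand explains the standing of compound 2 or the lack of separation among the other three.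

Going by these compounds, it remains open whether a carboxylic acid or a primary amine on the aromatic ring, or a longer alkyl chain in place of the ring on the triple-bonded carbon, would move the number clear of this narrow band. The pyridin-2-yl and pyridin-4-yl isomers also leave a question: whether the place of the ring nitrogen matters, as the place of the fluoro does between compound 1 and compound 2.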